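Phenyl for 1-benzofuran-2-yl: notes on four analogues

The source may hold more compounds than are shown below. What is called first, only, known or untested is meant among the compounds shown, and "the series" means these compounds.

Measured so far in a functional assay on A549 cells (Homo sapiens), read by MTT assay, with a stated time of 72 h; on this read-out higher numbers stand for weaker inhibition and lower numbers for stronger inhibition:
compound 1 `CNc1ncnc2c1c(-c1ccccc1)cn2[C@@H]1O[C@H](CO)[C@@H](O)[C@H]1O`, compound 1 gives > 20000 nM, a limit of the assay.
compound 2 `O=c1[nH]cnc2c1c(-c1cc3ccccc3o1)cn2[C@@H]1O[C@H](CO)[C@@H](O)[C@H]1O`, compound 2 gives > 20000 nM, a limit of the assay.
compound 3 `CNc1ncnc2c1c(-c1cc3ccccc3o1)cn2[C@@H]1O[C@H](CO)[C@@H](O)[C@H]1O`, compound 3 gives > 20000 nM, a limit of the assay.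

None of the three returns a number in this assay; all sit at the limit of > 20000 nM in this assay, at which 3 of the 3 values shown sit. Within that, the step that the two limits leave unreadable from compound 3 to compound 1, made by phenyl in place of 1-benzofuran-2-yl on an aromatic carbon, cannot be sized. How the core of compound 2 differs from that of compound 3 is not broken down here; both ends merely share the limit.

Compound 4 `O=c1[nH]cnc2c1c(-c1ccccc1)cn2[C@@H]1O[C@H](CO)[C@@H](O)[C@H]1O` remains to be measured. It arises from compound 2 by phenyl in place of 1-benzofuran-2-yl on an aromatic carbon, the same change at the same place as the one already seen. The step from compound 2 to compound 4 in this assay is expected to be a step that the limit leaves unreadable from compound 2 to compound 4. That expectation rests on the measured pair, whose step that the two limits leave unreadable from compound 3 to compound 1 left both ends at the limit, giving no sign that the change brings a compound into the readable range. Compound 4 is accordingly estimated at 30000 nM, most likely again reported only as a limit, with an expected span from 10000 nM to 100000 nM.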

Compound 4, half-maximal inhibitory concentration: > 100000 nM
Compound 4 ended at the assay's limit (the forecaster's own chance of this, stated with the estimate: 85%); middle value at least 3.3-fold (0.52 log units) from the limit.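

In this assay compound 4 gives > 100000 nM, a limit and not a number. Compound 2 gives > 20000 nM, also a limit, so no step can be read between compound 2 and compound 4. The compounds shown leave open whether phenyl in place of 1-benzofuran-2-yl changes inhibition at all in this assay.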